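Adding a second trifluoromethyl to compound 3

The source may report more compounds than this note shows. Statements on the series, on what has been measured and on what is new or still open speak of the compounds shown alone.

In a functional assay on CCRF-CEM cells (Homo sapiens) for inhibition, read by MTT assay, with a stated time of 72 h (a higher number here means a weaker inhibitor, a lower number a stronger inhibitor), three compounds have been measured. Compound 1 `COc1cc(NC(C)CCCNC(=O)NNC(=O)Nc2cccc(F)c2)c2ncccc2c1` gives 98000 nM, compound 2 `COc1cc(NC(C)CCCNC(=O)NNC(=O)Nc2ccc(Cl)cc2)c2ncccc2c1` gives 108000 nM, and compound 3 `COc1cc(NC(C)CCCNC(=O)Nc2cccc(C(F)(F)F)c2)c2ncccc2c1` gives 19000 nM, the lowest of the three numbers. The steps of a 5.2-fold lower number from compound 1 to compound 3 (0.71 log units; beyond the scatter) and a 5.7-fold lower number from compound 2 to compound 3 (0.75 log units; beyond the scatter) both lead to compound 3. Compound 4 `COc1cc(NC(C)CCCNC(=O)Nc2cc(C(F)(F)F)cc(C(F)(F)F)c2)c2ncccc2c1` differs from compound 3 by trifluoromethyl in place of hydrogen on an aromatic carbon. Among the measured compounds shown here, none of the measured steps concerns a second trifluoromethyl on this ring; the two steps known all exchange the whole group on the amide-type nitrogen, so they give no direction for this smaller change. The expected step is therefore no change at the digits printed from compound 3 to compound 4 (within the scatter), within the scatter. Compound 4 is estimated at 19000 nM, with a range from 6000 nM to 60000 nM.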

Compound 4, half-maximal inhibitory concentration: 4100 nM
Estimate against measurement, compound 4: 4.6-fold (0.67 log units) above; measured number below the stated range.
By their numbers in this assay, from the lowest: compound 4; then compound 3; then compounds 1 and 2 (each within the scatter of the next).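

In this assay, putting trifluoromethyl in place of hydrogen on this aromatic carbon gives a 4.6-fold lower number from compound 3 to compound 4 (0.67 log units; beyond the scatter). Among the compounds shown here, this shows that a small change on the ring can shift the number on its own, whereas the earlier steps exchanged the whole group on the amide-type nitrogen. Nothing available explains why the number falls.

On these data alone, whether a smaller group such as methyl, or a nitrile or an amine, at this position would lower the number as well remains open.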